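Swapping a Pyridyl Arm for Thiophene on the Shared Core

A few compounds are considered here, and "the series" means these few. Any claim that something is new, unique, unknown or untested is made for them only; others in the source may bear on it.

Compound 1 `Oc1cccc(-c2cc(-c3cccc(Cl)c3)nc(-c3ccccn3)c2)c1` carries a pyridin-2-yl group on its core; in a functional assay on DU-145 cells (Homo sapiens) for cytotoxicity, read by CCK-8 assay and cell counting, with a stated time of 2 days (on this read-out lower numbers stand for stronger inhibition and higher numbers for weaker inhibition), compound 1 gives "not determined" (no result reported), so its own standing cannot be placed. The only measured relative, compound 2 `Oc1cccc(-c2cc(-c3ccc(Cl)cc3)nc(-c3ccccn3)c2)c1`, gives 8090 nM in this assay. Compound 3 `Oc1cccc(-c2cc(-c3ccsc3)nc(-c3cccc(Cl)c3)c2)c1` is the compound still to be measured; it is compound 1 with thiophen-3-yl in place of pyridin-2-yl on an aromatic carbon. Going by the values given here, no pair of measured compounds differs in this way. Among the compounds with values here, no step for the change is known, and the effect of swapping the six-membered arm for the five-membered one cannot be read from the data. The expectation is therefore a step of modest size in either direction, quite possibly none beyond the usual scatter. Compound 3 is estimated to give about 9000 nM in this assay, with a plausible range from 2000 nM to 40000 nM.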

Compound 3, half-maximal inhibitory concentration: 3330 nM
The estimate for compound 3 lay 2.7-fold (0.43 log units) above the measured number; measured number inside the range.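

Going by these compounds alone, compound 1 has no single number in this assay; no step to compound 3, at 3330 nM, can be read. The compounds shown leave open what replacing pyridin-2-yl with thiophen-3-yl does on the shared core. No supporting evidence bears on this result.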